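The source may report more compounds than this note shows. Statements on the series, on what has been measured and on what is new or still open speak of the compounds shown alone.

Compound 1 `O=c1cc(I)n([C@@H]2O[C@H](CO)[C@@H](O)[C@H]2O)c(=O)[nH]1`: 15300 nM
Compound 2 `O=Cc1cc(=O)[nH]c(=O)n1[C@@H]1O[C@H](CO)[C@@H](O)[C@H]1O`: > 50000 nM (a limit)

Among the compounds with values here, in a functional assay on ML1 cells (Homo sapiens) for antiproliferative activity, read by WST assay, with a stated time of 3 days (on this read-out lower numbers stand for stronger inhibition and higher numbers for weaker inhibition), compound 1 gives 15300 nM, the only actual number so far. The result for compound 2 is a limit of the assay, > 50000 nM. Compound 3 `O=c1[nH]c(=O)n([C@@H]2O[C@H](CO)[C@@H](O)[C@H]2O)c(I)c1Br` departs from compound 1 by a single change: bromo in place of hydrogen on an aromatic carbon, with bromo in place of hydrogen on an aromatic carbon, ortho to an iodo group. Within the data shown here, the one measured step, an at least 3.2-fold higher number from compound 1 to compound 2 (0.51 log units; beyond the scatter), puts formyl in place of iodo. Among the measured compounds shown here, compound 3 keeps that iodo group, so this step bears on the new change only indirectly, and no measured step concerns the carbon that takes the bromo. No shift beyond the scatter is therefore expected in this assay, and the expected step is a 1.4-fold higher number from compound 1 to compound 3 (0.16 log units; within the scatter). Compound 3 is estimated at 22000 nM, with an expected range of 7000 nM to 60000 nM.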

Compound 3, half-maximal inhibitory concentration: > 50000 nM
Compound 3 was reported as a limit; the forecaster's own chance of this, stated with the estimate: 35%; middle value at least 2.2-fold (0.35 log units) from the limit.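

Within the data shown here, this is the first change at the carbon ortho to an iodo group, and in this assay bromo in place of hydrogen gives an at least 3.2-fold higher number from compound 1 to compound 3 (0.51 log units; beyond the scatter). Compound 3 keeps the iodo group, so a change at this carbon alone is enough to weaken the result, as formyl in place of iodo did in an at least 3.2-fold higher number from compound 1 to compound 2 (0.51 log units; beyond the scatter). The value of compound 3, > 50000 nM, is a limit of the assay, so the step gives only a minimum size: the limit of > 50000 nM in this assay, at which 2 of the 3 values shown sit.

Only hydrogen and bromo are shown at this carbon, and whether the loss belongs to bromo itself or would follow any larger group stays open. From the compounds shown here alone, how chloro, methyl or an amine would read at this carbon also remains unknown, as does how far compound 3 lies past the limit.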